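A few compounds are considered here, and "the series" means these few. Any claim that something is new, unique, unknown or untested is made for them only; others in the source may bear on it.

Measured in an assay on isolated protein for inhibition of Polyunsaturated fatty acid 5-lipoxygenase (Homo sapiens), read by HPLC, with a stated time of 10 min; on this read-out higher numbers stand for weaker inhibition and lower numbers for stronger inhibition:
Compound 1 `Cc1cc(OCc2nc3ccccc3s2)ccc1NC(=O)Nc1cccc(Cl)c1`: 160 nM
Compound 2 `Cc1cc(OCc2nc3ccccc3s2)ccc1NC(=O)Nc1ccc(Cl)cc1`: 570 nM
Compound 3 `Cc1cc(NC(=O)Nc2cccc(Cl)c2)ccc1OCc1nc2ccccc2s1`: 2090 nM

Compound 1 and compound 2 share a core and differ by 4-chlorophenyl in place of 3-chlorophenyl on an amide-type nitrogen; that change gives a 3.6-fold higher number from compound 1 to compound 2 (0.55 log units; beyond the scatter). Compound 3 carries the same atoms as compound 1 joined differently, and the difference between the two cores is not broken down here; compound 3 stands highest of the three in this assay.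

Compound 4 `Cc1cc(NC(=O)Nc2ccc(Cl)cc2)ccc1OCc1nc2ccccc2s1` is not yet measured. It differs from compound 3 by 4-chlorophenyl in place of 3-chlorophenyl on an amide-type nitrogen, the same change as from compound 1 to compound 2, at the same kind of place. The expected step for compound 4 in this assay is a 3.3-fold higher number from compound 3 to compound 4 (0.52 log units; beyond the scatter), a size resting on the earlier step of a 3.6-fold higher number from compound 1 to compound 2 (0.55 log units; beyond the scatter), with the core of compound 3 as the untested part. Compound 4 is estimated at 7000 nM, between 2500 nM and 20000 nM.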

Compound 4, half-maximal inhibitory concentration: > 10000 nM
Compound 4 ended at the assay's limit; the forecaster's own chance of this, stated with the estimate: 20%; middle value at least 1.4-fold (0.15 log units) from the limit.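

In this assay, 4-chlorophenyl in place of 3-chlorophenyl on an amide-type nitrogen again raises the number on the second core, giving an at least 4.7-fold higher number from compound 3 to compound 4 (0.67 log units; beyond the scatter). Compound 4 stands at a limit of the assay and not at a number: the limit of > 10000 nM in this assay, at which 1 of the 4 values shown sits. The direction of the change therefore carries from one core to the other in this pair, but the data do not show that its size carries over: the same change on two cores in this assay, a 3.6-fold higher number (0.55 log units; beyond the scatter) from compound 1 to compound 2 and an at least 4.7-fold higher number (0.67 log units; beyond the scatter) from compound 3 to compound 4; the limit leaves it open whether they differ.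

The compounds shown leave open where the true value of compound 4 lies and whether the change weighs more on the core of compound 3. They also leave open how a bromophenyl or methoxyphenyl group on that amide-type nitrogen would behave on either core.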